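The source may report more compounds than this note shows. Statements on the series, on what has been measured and on what is new or still open speak of the compounds shown alone.

Compound 1 `Cn1ccnc1/C=C/C(=O)/C=C/c1coc2ccccc2c1=O`: 2300 nM
Compound 2 `CCCCn1ccnc1/C=C/C(=O)/C=C/c1coc2ccccc2c1=O`: 2000 nM
Compound 3 `CC(C)n1ccnc1/C=C/C(=O)/C=C/c1coc2ccccc2c1=O`: 1200 nM

These numbers come from a functional assay on LNCaP cells (Homo sapiens) for inhibition, read by WST assay, with a stated time of 3 days; on this read-out higher numbers stand for weaker inhibition and lower numbers for stronger inhibition. Compound 2 gives 2000 nM, and all three compounds lie within the usual scatter of one another.

Compound 4 `CC(C)CCn1ccnc1/C=C/C(=O)/C=C/c1coc2ccccc2c1=O` differs from compound 2 only in its butyl chain, which becomes isopentyl: methyl in place of hydrogen on a saturated chain carbon bound to two saturated chain carbons. That is methyl in place of hydrogen on a saturated chain carbon bound to two saturated chain carbons.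

The closest evidence comes from changing the group on the aromatic nitrogen: a 1.2-fold lower number from compound 1 to compound 2 (0.06 log units; within the scatter), a 1.9-fold lower number from compound 1 to compound 3 (0.28 log units; within the scatter) and a 1.7-fold lower number from compound 2 to compound 3 (0.22 log units; within the scatter). None of these steps goes beyond the scatter, so no clear change is expected here either.

The expected step is a 1.1-fold lower number from compound 2 to compound 4 (0.05 log units; within the scatter).

For compound 4 the estimate is 1800 nM, with an expected range of 900 nM to 3500 nM.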

Compound 4, half-maximal inhibitory concentration: 4000 nM
Compound 4: the middle estimate sits 2.2-fold (0.35 log units) below what was measured, outside the stated range (above it).
By their numbers in this assay, from the lowest: compounds 3, 2, 1 and 4 (each within the scatter of the next, the first and the last beyond it).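

Methyl in place of hydrogen on the butyl chain gives a 2.0-fold higher number from compound 2 to compound 4 (0.30 log units; within the scatter) and the comparison with the smallest group gives a 1.7-fold higher number from compound 1 to compound 4 (0.24 log units; within the scatter), so neither step clearly separates the compounds. For the compounds shown here, only a 3.3-fold higher number from compound 3 to compound 4 (0.52 log units; beyond the scatter) passes beyond the scatter, the first step here to do so, which shows that the group on the aromatic nitrogen can shift the number modestly. Nothing shown explains that gap. Still open, on these data alone, is whether an amine, a carboxylic acid or a longer chain on that nitrogen would shift it further.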